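The compounds below may be only part of what the source reports. "The series", "measured", "known", "first", "only" and "open" are said of these compounds alone.

Measured in a functional assay on T47D cells (Homo sapiens) for antiproliferative activity, read by MTT assay, with a stated time of 72 h; on this read-out lower numbers stand for stronger inhibition and higher numbers for weaker inhibition:
- compound 1 `CCCn1ccnc1-c1cc(OC)c(OC)c(OC)c1`: > 100000 nM
- compound 2 `COc1cc(-c2nccn2S(=O)(=O)c2ccc(C)cc2)cc(OC)c1OC`: > 100000 nM

Compound 1 stands at a limit of this assay, > 100000 nM, and not at a number. Compound 2 likewise gives only a limit, > 100000 nM. The record so far shows (the limit of > 100000 nM in this assay, at which 2 of the 2 values shown sit).

Compound 3 `COc1cc(-c2nccn2-c2ccc(C)cc2)cc(OC)c1OC` carries 4-methylphenyl in place of propyl on an aromatic nitrogen, (4-methylphenyl in place of propyl on an aromatic nitrogen). No measured step sizes this change, and compound 3 may also end at the limit. In this assay, a modest move toward stronger inhibition is expected, estimated as an at least 2.5-fold lower number from compound 1 to compound 3 (0.39 log units; beyond the scatter). For compound 3 the estimated value is 40000 nM, with an expected range from 8000 nM to 100000 nM.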

Compound 3, half-maximal inhibitory concentration: 20500 nM
Compound 3: the middle estimate sits 2.0-fold (0.29 log units) above what was measured; low and high end bracket the measured number.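

Among the compounds shown here, on this aromatic nitrogen, 4-methylphenyl in place of propyl gives the first measured number in this assay, a change of an at least 4.8-fold lower number from compound 1 to compound 3 (0.68 log units; beyond the scatter). For compound 1, the value of > 100000 nM is a limit. Compound 3 is the only compound shown that stands off this limit: the limit of > 100000 nM in this assay, at which 2 of the 3 values shown sit.

From the compounds shown here alone, it remains open whether the aromatic ring alone or also its methyl carries the change. Going by these compounds, how a plain phenyl, a benzyl or a 4-methoxyphenyl group on this nitrogen would read also remains open.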